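The source may report more compounds than this note shows. Statements on the series, on what has been measured and on what is new or still open speak of the compounds shown alone.

In a functional assay on A549 cells (Homo sapiens) for inhibition, read by MTT assay, with a stated time of 72 h (on this read-out higher numbers stand for weaker inhibition and lower numbers for stronger inhibition), compound 2 `COc1cc(OC)cc(N2CCN(C(=O)c3oc(C)nc3-c3ccccc3F)CC2)c1` gives 27 nM as the lowest of three numbers, with compound 1 `Cc1nc(-c2ccccc2F)c(C(=O)N2CCN(c3cc(Cl)cc(Cl)c3)CC2)o1` at 204 nM and compound 3 `CCC[C@H](Nc1nc(-c2ccc(NC(=O)NCC)c(OC)c2)ncc1C)c1cccnc1` at 338 nM above it. Compound 4 `COc1cc(OC)cc(N2CCN(C(=O)c3oc(C)nc3-c3cccc(F)c3)CC2)c1` departs from compound 2 in one place: 3-fluorophenyl in place of 2-fluorophenyl on an aromatic carbon with 3-fluorophenyl in place of 2-fluorophenyl on an aromatic carbon. For the measured compounds named here, the only measured step (a 7.6-fold lower number from compound 1 to compound 2 (0.88 log units; beyond the scatter)) exchanged a different group, so it shows that these numbers can move but gives no direct guide to moving the fluorine. In this assay a step within the scatter is therefore expected, if anything toward a higher number. The estimated step is a 1.7-fold higher number from compound 2 to compound 4 (0.22 log units; within the scatter) and remains an expectation. For compound 4 the estimated value is 45 nM with an expected range from 14 nM to 150 nM here.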

Compound 4, half-maximal inhibitory concentration: 98 nM
Compound 4: the middle estimate sits 2.2-fold (0.34 log units) below what was measured; the range from low to high includes it.
By their numbers in this assay, from the lowest: compound 2; then compound 4; then compounds 1 and 3 (each within the scatter of the next).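

Where the earlier step exchanged a different group, this one shows that in this assay the number also responds to the place of the fluorine alone, with a 3.6-fold higher number from compound 2 to compound 4 (0.56 log units; beyond the scatter) for 3-fluorophenyl in place of 2-fluorophenyl. The two groups have the same atoms, so a rearrangement within this group is enough to move the number beyond the scatter. Of these two groups, 2-fluorophenyl gives the lower number. From the compounds shown here alone, whether 4-fluorophenyl, unsubstituted phenyl or a methoxy group in place of the fluorine would give a lower number remains open. No measurement given here explains the difference between the two fluorine placements.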